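A Pyrimidinyl for a Phenyl on Compound 3

The source may hold more compounds than are shown below. What is called first, only, known or untested is meant among the compounds shown, and "the series" means these compounds.

compound 1, `O=C(Nc1ccc([N+](=O)[O-])cc1)Nc1cccc(NC(=O)c2ccccn2)c1`: 320 nM
compound 2, `Cc1ccc(NC(=O)Nc2cccc(NC(=O)c3ccccn3)c2)cc1`: 20 nM
compound 3, `O=C(CCSC(=S)N1CCN(c2ccccc2)CC1)Nc1cccc(NC(=O)c2ccccn2)c1`: 31700 nM

In a functional assay on A549 cells (Homo sapiens) for antiproliferative activity, read by MTT assay, with a stated time of 48 h (a lower number here means a stronger inhibitor, a higher number a weaker inhibitor), compound 3 stands at the highest number of the three, far from compound 1 and further still from compound 2. Compound 4, `O=C(CCSC(=S)N1CCN(c2ncccn2)CC1)Nc1cccc(NC(=O)c2ccccn2)c1`, differs from compound 3 by pyrimidin-2-yl in place of phenyl on an amine nitrogen in a ring. Within the data shown here, the only measured step, a 16-fold lower number from compound 1 to compound 2 (1.20 log units; beyond the scatter), concerns a substituent on a different ring and does not bear on this exchange, so no guide exists for the size or direction of the step. On that basis compound 4 is expected to stay close to compound 3, with an estimated 1.1-fold lower number from compound 3 to compound 4 (0.02 log units; within the scatter) within the scatter. Compound 4 is estimated at 30000 nM, within 10000 nM to 100000 nM.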

Compound 4, half-maximal inhibitory concentration: 460 nM
Compound 4: middle estimate off by 65-fold (1.81 log units), on the high side, and the stated range ends above it.
By their numbers in this assay, from the lowest: compound 2; then compounds 1 and 4 (each within the scatter of the next); then compound 3.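

In this assay, pyrimidin-2-yl in place of phenyl on an amine nitrogen in a ring gives a 69-fold lower number from compound 3 to compound 4 (1.84 log units; beyond the scatter). This shows that this position, which the earlier step did not touch, strongly affects the read-out, even in an exchange that keeps the heavy-atom count and adds two ring nitrogens and two hydrogen-bond acceptors. No measurement shown here accounts for the size of this step. From the compounds shown here alone, whether pyridin-2-yl, with a single ring nitrogen, or a small alkyl group such as methyl on the same nitrogen would match pyrimidin-2-yl remains open.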